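The compounds below may be only part of what the source reports. "The series", "measured", "known", "first", "only" and "open" are said of these compounds alone.

Measured so far:
- compound 1, `Cn1nc(COc2cccc(F)c2)c2c1CCN(C(=O)Nc1ccc(Cl)cc1)C2`: 6600 nM
- compound 2, `Cn1nc(COc2cc(F)cc(F)c2)c2c1CCN(C(=O)Nc1ccc(Cl)cc1)C2`: 3100 nM

In an assay on cells for inhibition of Pendrin (Mus musculus), read by fluorescence, with a stated time of 10 min (a lower number here means a stronger inhibitor, a higher number a weaker inhibitor), compound 2 gives the lowest of the two numbers; its nearest neighbour is compound 1, which differs by a second fluoro in place of hydrogen on an aromatic carbon, a step of a 2.1-fold lower number from compound 1 to compound 2 (0.33 log units; beyond the scatter). Compound 3, `Cn1nc(COc2cc(F)cc(F)c2)c2c1CCN(C(=O)NC(=O)c1ccccc1)C2`, has not yet been measured. It differs from compound 2 in one place: benzoyl in place of 4-chlorophenyl on an amide-type nitrogen. Neither measured step bears on this change; the one step known, from compound 1 to compound 2, touches a different part of the molecule, so nothing shown says whether a benzoyl in place of the 4-chlorophenyl on the urea nitrogen helps or hurts. With no guide, the expected step of a 1.6-fold higher number from compound 2 to compound 3 (0.21 log units; within the scatter) is small and uncertain, with a wide range. Compound 3 is therefore expected to give about 5000 nM in this assay, somewhere between 1500 nM and 20000 nM.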

Compound 3, half-maximal inhibitory concentration: > 10000 nM
Compound 3 ended at the assay's limit (the forecaster's own chance of this, stated with the estimate: 25%); at least 2.0-fold (0.30 log units) between middle value and limit.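

Swapping 4-chlorophenyl for benzoyl on the amide-type nitrogen gives an at least 3.2-fold higher number from compound 2 to compound 3 (0.50 log units; beyond the scatter) in this assay, so this position does respond to what it carries, which the earlier pair could not show because its fluoro change lay in a different part of the molecule. Compound 3 gives > 10000 nM, which is a limit of the assay and not a number. The full size of the loss cannot be read, because compound 3 sits at that limit: the limit of > 10000 nM in this assay, at which 1 of the 3 values shown sits.

The change removes the chlorine and adds a carbonyl in a single step, so the compounds shown do not say which of the two matters. A plain phenyl group, or a benzoyl that keeps the chlorine, would separate them.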